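A few compounds are considered here, and "the series" means these few. Any claim that something is new, unique, unknown or untested is made for them only; others in the source may bear on it.

Of the compounds shown here, three of this set have so far been measured in a functional assay on OVCAR-5 cells (Homo sapiens) for inhibition, read by sulforhodamine B assay, with a stated time of 48 h; on this read-out higher numbers stand for weaker inhibition of growth and lower numbers for stronger inhibition of growth. Compound 1 `COc1cc(C)cc(-c2c(-c3ccnc(-c4ccc(C(C)=O)cc4)c3)cnn2CC#N)c1` gives > 100000 nM, which is a limit of the assay and not a number (the limit of > 100000 nM in this assay, at which 1 of the 3 values shown sits). Compound 2 `Cc1cc(O)cc(-c2nn(CC#N)cc2-c2ccnc(-c3ccc(Oc4ccccc4)cc3)c2)c1` gives 4840 nM. Compound 3 `COc1cc(C)cc(-c2nn(CC#N)cc2-c2ccnc(-c3ccc(N(C)C)cc3)c2)c1` gives 3980 nM; of the two numbers shown this is the lower one, but the gap to compound 2 lies within the scatter. Compound 4 `Cc1cc(O)cc(-c2nn(CC#N)cc2-c2ccnc(-c3ccc(N(C)C)cc3)c2)c1` has not yet been measured. It differs from compound 3 by hydrogen in place of methyl on an oxygen on an aromatic ring. Among the measured compounds shown here, no pair of measured compounds differs in this place alone, so the step has no direct precedent; compound 2 and compound 3, which carry the two oxygen groups beside different other substituents, give numbers within the scatter of each other. The step from compound 3 to compound 4 is expected to be a 1.0-fold higher number from compound 3 to compound 4 (0.00 log units; within the scatter), nothing beyond the scatter. Compound 4 is therefore estimated at 4000 nM, with a range from 1500 nM to 11000 nM.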

Compound 4, concentration for 50% growth inhibition: 1490 nM
For compound 4 the middle estimate is 2.7-fold (0.43 log units) above the measured one, outside the stated range (below it).
By their numbers in this assay, from the lowest: compound 4; then compounds 3 and 2 (each within the scatter of the next). At a limit, above all of these: compound 1.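

In this assay the change from methoxy to hydroxy on the 3-methoxy-5-methylphenyl group gives a 2.7-fold lower number from compound 3 to compound 4 (0.43 log units; beyond the scatter) and so shows that this oxygen substituent affects the read-out. With the hydroxy group held constant, dimethylamino in place of phenoxy on an aromatic carbon gives a 3.2-fold lower number from compound 2 to compound 4 (0.51 log units; beyond the scatter) and shows that this second place matters too. No measurement shown explains either step. From the compounds shown here alone, what an ethoxy group or an amine would give on that ring remains open, as does whether the step from methoxy to hydroxy keeps its size with phenoxy in the other place.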